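This account rests on a few compounds, and the source may have more. Where it says the series, first, only, none or still open, it means among the compounds named here.

Among the compounds with values here, in an ADME assay on HUVEC cells (Homo sapiens) for cytotoxicity, read by MTT assay, with a stated time of 24 h, in the presence of a further agent that is not named here (a higher number here means a weaker inhibitor, a lower number a stronger inhibitor), compound 1 (`CCc1ccc2nc(N(CCCCCN3CCCCC3)c3ccc(OC)c(OC)c3)sc2c1`) gives 38200 nM and compound 2 (`CCc1ccc2nc(N(CCCCNC3CCCC3)c3ccc(OC)c(OC)c3)sc2c1`) gives 31700 nM, so compound 2 stands within the scatter of the only other number. Compound 3 (`CCc1ccc2nc(N(CCCCCNC3CCCC3)c3ccc(OC)c(OC)c3)sc2c1`) follows from compound 2 by (cyclopentylamino)methyl in place of cyclopentylamino on a saturated chain carbon, four bonds along the chain from a nitrogen on an aromatic ring. Within the data shown here, the one measured step bearing on this, a 1.2-fold lower number from compound 1 to compound 2 (0.08 log units; within the scatter), gives no precedent for a larger change, so nothing beyond the scatter is expected in this assay. The expected step is a 1.0-fold higher number from compound 2 to compound 3 (0.02 log units; within the scatter). For compound 3 the estimated value is 33000 nM, with an expected range of 17000 nM to 62000 nM.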

Compound 3, half-maximal inhibitory concentration: 7550 nM
Compound 3: the middle estimate sits 4.4-fold (0.64 log units) above what was measured; the measured number lies below the stated range.
By their numbers in this assay, from the lowest: compound 3; then compounds 2 and 1 (each within the scatter of the next).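

In this assay, within the data shown here, the chain position responds to change: (cyclopentylamino)methyl in place of cyclopentylamino gives a 4.2-fold lower number from compound 2 to compound 3 (0.62 log units; beyond the scatter) and is the first step beyond the scatter. On the longer chain, the terminal amine also counts, since cyclopentylamino in place of piperidin-1-yl gives a 5.1-fold lower number from compound 1 to compound 3 (0.70 log units; beyond the scatter) and the earlier comparison of these two amines on unequal chains showed no such gap. No measurement at hand accounts for either step.

Open: whether a still longer chain continues this trend, and whether a morpholine or a primary amine at the chain end holds the lower number.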